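A few compounds are considered here, and "the series" means these few. Any claim that something is new, unique, unknown or untested is made for them only; others in the source may bear on it.

Working notes on a small antiproliferative series. Two analogues have been measured in a functional assay on HCT-116 cells (Homo sapiens) for antiproliferative activity, read by MTT assay, with a stated time of 72 h; a higher number here means a weaker inhibitor, a lower number a stronger inhibitor. Compound 1 `CCN(CC)C(=N)NC(=N)Nc1ccc(F)c(F)c1` gives 39400 nM in this assay, the highest of the two numbers recorded so far. Compound 2 `CC(C)CNC(=N)NC(=N)Nc1ccc(F)cc1F` carries an isobutylamino group on an aromatic ring whose fluorine placement differs from that of compound 1; in this assay compound 2 gives 21100 nM. The gap between compound 2 and compound 1 sits within the scatter of repeated measurements, so no order between the two is claimed.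

Compound 3 `CC(C)CNC(=N)NC(=N)Nc1ccc(F)c(F)c1` has not yet been measured in this assay. Compared with compound 1 the change is isobutylamino in place of diethylamino on a carbon with a double bond to nitrogen. Going by the values given here, no measured pair differs in exactly this one place, so there is no directly comparable step to lean on. Compound 2 already carries isobutylamino, and its 21100 nM lies within the scatter of compound 1, which gives no indication that the amine change alone moves the number beyond the scatter. The step of a 1.4-fold lower number from compound 1 to compound 3 (0.15 log units; within the scatter) is therefore expected to be small, with no direction favoured beyond the scatter. Compound 3 is estimated at 28000 nM, with a range from 9000 nM to 80000 nM.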

Compound 3, half-maximal inhibitory concentration: 29700 nM
For compound 3 the middle estimate is 1.1-fold (0.03 log units) below the measured one, and the stated range covers the measured number.
By their numbers in this assay, from the lowest: compounds 2, 3 and 1 (each within the scatter of the next).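

Going by these compounds alone, with the fluorine-bearing aromatic ring left unchanged, the step of a 1.3-fold lower number from compound 1 to compound 3 (0.12 log units; within the scatter) gives the first direct reading of isobutylamino in place of diethylamino on a carbon with a double bond to nitrogen in this assay and isolates this change from any difference elsewhere in the molecule. Both groups count the same heavy atoms, while isobutylamino brings a hydrogen-bond donor that diethylamino lacks, and in this pair that exchange does not carry the number beyond the scatter. No measurement in hand bears on the reason for this result.

Still open, from the compounds shown here alone, is whether any other amine group at this place would move the number beyond the scatter, for example a longer chain such as octylamino, a cyclic amine such as piperidine, or a chain ending in a carboxylic acid. Also open, going by these compounds, is whether the aromatic ring can shift the number beyond the scatter when another group, such as trifluoromethyl or chlorine, stands in place of fluorine on the shared core.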